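Anilinopyrimidine series: imidazolylethoxy swap carried onto thienyl core

A few compounds are considered here, and "the series" means these few. Any claim that something is new, unique, unknown or untested is made for them only; others in the source may bear on it.

Three compounds carry a number in a functional assay for inhibition, with Homo sapiens as the target; on this read-out higher numbers stand for weaker inhibition and lower numbers for stronger inhibition. Compound 1 `c1ccc(-c2ccnc(Nc3cccc(OCCn4ccnc4)c3)n2)nc1` gives 400 nM. Compound 2 `Cc1cccc(Nc2nccc(-c3ccccn3)n2)c1` gives 700 nM. Compound 3 `Cc1cccc(Nc2nccc(-c3cccs3)n2)c1` gives 300 nM, the lowest of the three, though compound 1 lies within the scatter of it.

Two single-point changes connect them. Compound 1 differs from compound 2 by 2-(1H-imidazol-1-yl)ethoxy in place of methyl on an aromatic carbon, and the step of a 1.8-fold lower number from compound 2 to compound 1 (0.24 log units; within the scatter). Compound 3 differs from compound 2 by thiophen-2-yl in place of pyridin-2-yl on an aromatic carbon, and the step of a 2.3-fold lower number from compound 2 to compound 3 (0.37 log units; beyond the scatter).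

Compound 4 `c1cc(Nc2nccc(-c3cccs3)n2)cc(OCCn2ccnc2)c1` is not yet measured. For the measured compounds named here, it differs from compound 3 by 2-(1H-imidazol-1-yl)ethoxy in place of methyl on an aromatic carbon, the same kind of change as the one from compound 2 to compound 1, now made on the core of compound 3, which differs from the core of compound 2 by thiophen-2-yl in place of pyridin-2-yl on an aromatic carbon. The two places are described in the same words.

From compound 3 to compound 4 the step is expected to be a 1.7-fold lower number from compound 3 to compound 4 (0.22 log units; within the scatter), resting on the step of a 1.8-fold lower number from compound 2 to compound 1 (0.24 log units; within the scatter) and on compound 3 at 300 nM. Compound 4 is expected to give about 180 nM, between 70 nM and 450 nM.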

Compound 4, half-maximal inhibitory concentration: 100 nM
Compound 4: the middle estimate sits 1.8-fold (0.26 log units) above what was measured, within the range that was stated.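

Carried onto the core of compound 3, 2-(1H-imidazol-1-yl)ethoxy in place of methyl gives in this assay a 3.0-fold lower number from compound 3 to compound 4 (0.48 log units; beyond the scatter) and keeps the direction seen on the core of compound 2: the same change on two cores in this assay, a 1.8-fold lower number (0.24 log units; within the scatter) from compound 2 to compound 1 and a 3.0-fold lower number (0.48 log units; beyond the scatter) from compound 3 to compound 4, 1.7-fold (0.23 log units) apart, within the scatter of two such steps.

Read the other way, thiophen-2-yl in place of pyridin-2-yl gives a 4.0-fold lower number from compound 1 to compound 4 (0.60 log units; beyond the scatter) on the core that already holds the imidazolylethoxy group, and this step too agrees with its counterpart: the same change on two cores in this assay, a 2.3-fold lower number (0.37 log units; beyond the scatter) from compound 2 to compound 3 and a 4.0-fold lower number (0.60 log units; beyond the scatter) from compound 1 to compound 4, 1.7-fold (0.23 log units) apart, within the scatter of two such steps.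

The two changes therefore combine here without a gap beyond the scatter, but this rests on one set of four compounds and one read-out, and it does not show that the step size would hold on any third core or why the number falls.

The compounds shown leave open which part of the 2-(1H-imidazol-1-yl)ethoxy group matters, since only this one group stands in place of methyl. A longer chain, or an amine such as morpholine in place of the imidazole, would separate the chain from the ring.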